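The source may hold more compounds than are shown below. What is called first, only, known or untested is meant among the compounds shown, and "the series" means these compounds.

Measured so far:
Compound 1 (`O=C(Nc1ccccn1)c1cccc(Nc2ncc(F)c(Nc3ccc(F)cc3)n2)c1`) gives 15300 nM
Compound 2 (`Cn1ccnc1NC(=O)c1cccc(Nc2ncc(F)c(Nc3ccc(F)cc3)n2)c1`) gives 10100 nM

Among the measured compounds shown here, in a functional assay on A549 cells (Homo sapiens) for antiproliferative activity, read by sulforhodamine B assay, with a stated time of 3 days (on this read-out lower numbers stand for stronger inhibition of growth and higher numbers for weaker inhibition of growth), compound 2 stands at 10100 nM and lies within the scatter of compound 1, the only other compound measured. Compound 3 (`COc1cc(NC(=O)c2cccc(Nc3ncc(F)c(Nc4ccc(F)cc4)n3)c2)cc(OC)c1`) carries 3,5-dimethoxyphenyl in place of 1-methyl-1H-imidazol-2-yl on an amide-type nitrogen. For the measured compounds named here, only one measured step bears on this place, and it stays within the scatter. Going by the values given here, no measured compound has a ring of carbon only at this nitrogen, so that step is a weak guide. Among the compounds with values here, with a 1.5-fold lower number from compound 1 to compound 2 (0.18 log units; within the scatter) as the sole evidence, no change beyond the scatter is expected in this assay and the estimated step is a 1.3-fold lower number from compound 2 to compound 3 (0.10 log units; within the scatter) with a wide margin on either side. For compound 3 the expected value is 8000 nM (estimated range 2000 nM to 25000 nM).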

Compound 3, concentration for 50% growth inhibition: 13900 nM
Estimate against measurement, compound 3: 1.7-fold (0.24 log units) below, and the stated range covers the measured number.
By their numbers in this assay, from the lowest: compounds 2, 3 and 1 (each within the scatter of the next).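

In this assay, 3,5-dimethoxyphenyl in place of 1-methyl-1H-imidazol-2-yl on the amide-type nitrogen gives a 1.4-fold higher number from compound 2 to compound 3 (0.14 log units; within the scatter), and 3,5-dimethoxyphenyl in place of pyridin-2-yl gives a 1.1-fold lower number from compound 1 to compound 3 (0.04 log units; within the scatter). The earlier compounds shown here carried only rings with nitrogen at this place, whereas this result shows that a six-membered aromatic ring of carbon only, with more heavy atoms and two oxygen atoms, also stays within the scatter of both. No measurement at hand accounts for these three groups reading alike.

On these data alone, it remains open whether the two methoxy groups matter here, which a plain phenyl would address. As far as these compounds go, it also remains open whether any group at this nitrogen leaves the scatter, such as a saturated ring like morpholine, a longer alkyl chain or a phenyl bearing a carboxylic acid.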